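Amide variation on the shared core: expecting compound 4

The source may report more compounds than this note shows. Statements on the series, on what has been measured and on what is new or still open speak of the compounds shown alone.

Measured in a functional assay on HepG2 cells (Homo sapiens) for cytotoxicity, read by MTT assay, with a stated time of 72 h; on this read-out lower numbers stand for stronger inhibition and higher numbers for weaker inhibition:
compound 1 `CN1[C@@H]2c3[nH]c4ccccc4c3C[C@H]1[C@H](C#N)N1[C@@H](CNC(=O)c3cccc(C(F)(F)F)c3)c3[nH]c4ccccc4c3C[C@@H]21` gives 340 nM
compound 2 `CN1[C@@H]2c3[nH]c4ccccc4c3C[C@H]1[C@H](C#N)N1[C@@H](CNC(=O)c3ccc4ccccc4n3)c3[nH]c4ccccc4c3C[C@@H]21` gives 110 nM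
compound 3 `CN1[C@@H]2c3[nH]c4ccccc4c3C[C@H]1[C@H](C#N)N1[C@@H](CNC(=O)c3cc4ccccc4[nH]3)c3[nH]c4ccccc4c3C[C@@H]21` gives 440 nM

Compound 3 carries the highest number of the three: a 4.0-fold higher number from compound 2 to compound 3 (0.60 log units; beyond the scatter) lies beyond the scatter, whereas a 1.3-fold higher number from compound 1 to compound 3 (0.11 log units; within the scatter) does not. Compound 4 `CN1[C@@H]2c3[nH]c4ccccc4c3C[C@H]1[C@H](C#N)N1[C@@H](CNC(=O)/C=C/c3cccc(C(F)(F)F)c3)c3[nH]c4ccccc4c3C[C@@H]21` is not yet measured; against compound 3 the change is 2-(3-(trifluoromethyl)phenyl)ethenyl in place of 1H-indol-2-yl on a carbonyl carbon, the carbonyl carbon otherwise bound only to the amide-type nitrogen. The step that bears on it is a 1.3-fold higher number from compound 1 to compound 3 (0.11 log units; within the scatter), which exchanges these two aryl groups directly on the carbonyl and stays within the scatter. Going by the values given here, compound 4 adds an ethenyl link for which no measured step exists. Little movement is expected: a 1.3-fold lower number from compound 3 to compound 4 (0.10 log units; within the scatter). Compound 4 is estimated at 350 nM, range 150 nM to 900 nM, in this assay.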

Compound 4, half-maximal inhibitory concentration: 540 nM
Beside the measured number, compound 4's estimate is 1.5-fold (0.19 log units) below it, and the stated range covers the measured number.
By their numbers in this assay, from the lowest: compound 2; then compounds 1, 3 and 4 (each within the scatter of the next).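

In this assay, the 2-(3-(trifluoromethyl)phenyl)ethenyl group on the carbonyl carbon gives no readable separation from the 3-(trifluoromethyl)phenyl or 1H-indol-2-yl groups: a 1.6-fold higher number from compound 1 to compound 4 (0.20 log units; within the scatter) and a 1.2-fold higher number from compound 3 to compound 4 (0.09 log units; within the scatter) both lie within the scatter. Quinolin-2-yl alone stands apart, with a 4.9-fold higher number from compound 2 to compound 4 (0.69 log units; beyond the scatter) beyond the scatter. No evidence is available to explain these values. Open, on these data alone, is whether a saturated two-carbon chain in place of the ethenyl link would read the same, and whether a quinolin-2-yl group on that ethenyl link would keep its separation. An amine or carboxylic acid on the aryl ring also remains untested among these compounds.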